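Three Shared-Core Anilines at the Assay Ceiling, and a Fourth

The source may hold more compounds than are shown below. What is called first, only, known or untested is meant among the compounds shown, and "the series" means these compounds.

Going by the values given here, the three compounds measured so far share one core and differ only in where fluorine sits. Compound 1 (`Fc1cccc(-c2nc(Nc3ccccc3)c3ccccc3n2)c1`) carries a fluorine on the phenyl ring attached to the core. Compound 2 (`Fc1ccc2nc(-c3ccccc3)nc(Nc3ccccc3)c2c1`) carries it instead on the core itself. Compound 3 (`Fc1cccc(Nc2nc(-c3cccc(F)c3)nc3ccc(F)cc23)c1`) combines fluorines at three positions. In a functional assay on COLO 205 cells (Homo sapiens) for cytotoxicity, read by MTT assay, with a stated time of 48 h (a lower number here means a stronger inhibitor, a higher number a weaker inhibitor), compound 1 gives > 50000 nM, which is a limit of the assay and not a number. In this assay compound 2 gives > 50000 nM, again a limit. In this assay compound 3 gives > 50000 nM, also a limit. So compound 3 stands exactly where the other two stand: at the ceiling (the limit of > 50000 nM in this assay, at which 3 of the 3 values shown sit), with no measurable potency among the three, and no step between measured compounds can be stated.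

Compound 4 (`Fc1cccc(-c2nc(Nc3ccc(Br)cc3)c3cc(F)ccc3n2)c1`) changes one thing: 4-bromophenyl in place of 3-fluorophenyl on a nitrogen on an aromatic ring, in words, 4-bromophenyl in place of 3-fluorophenyl on a nitrogen on an aromatic ring. Among the compounds with values here, since every value so far is a limit, there is no measured size of effect to lean on. The expected step is a number no higher from compound 3 to compound 4 (the limit leaves the size open), which means none beyond the scatter. Compound 4 is therefore estimated at 50000 nM, with a range from 15000 nM to 150000 nM, most likely reported again as a limit.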

Compound 4, half-maximal inhibitory concentration: > 50000 nM
Compound 4 ended at the assay's limit; the forecaster's own chance of this, stated with the estimate: 75%; the middle value lies on the limit itself.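

In this assay no step can be read from compound 3 to compound 4, as both results are limits of the assay and not numbers, and the same holds for every compound shown: the limit of > 50000 nM in this assay, at which 4 of the 4 values shown sit.

The compounds shown leave open how much 4-bromophenyl in place of 3-fluorophenyl matters, and whether any change to this shared core gives measurable potency.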